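The source may hold more compounds than are shown below. What is called first, only, known or untested is meant among the compounds shown, and "the series" means these compounds.

Metabolic stability across the series has been read in an ADME assay on microsomes from liver (Rattus norvegicus) for metabolic stability; a higher number here means that the compound lasts longer, a lower number that the compound disappears faster. Compound 1 `C/C(=C1/OC(=O)NC1=O)C(c1ccc(-c2ccc3cccc(F)c3c2)[nH]c1=O)C(C)C` reaches the limit of the assay, > 3 h, which is a limit rather than a number. Compound 2 `CCC(/C=C1\OC(=O)NC1=O)(CC)c1ccc(-c2ccc3cc(F)cc(F)c3c2)[nH]c1=O` likewise sits at the limit, > 3 h. Compound 3 `O=C1NC(=O)/C(=C/C(c2ccc(-c3ccc4cccc(F)c4c3)[nH]c2=O)C2CC2)O1` also returns only the limit, > 3 h; all three values shown share (the limit of > 3 h in this assay, at which 3 of the 3 values shown sit), so compound 3 cannot be placed relative to the others, only at the limit with them. The next compound, compound 4 `O=C1NC(=O)/C(=C/C(c2ccc(-c3ccc4cccc(F)c4c3)[nH]c2=O)C2CCCCC2)O1`, differs from compound 3 in one place: cyclohexyl in place of cyclopropyl on a saturated chain carbon bound to an aromatic carbon and a double-bonded chain carbon. Going by the values given here, no measured pair shows how this change moves this assay, so only a small step is expected in either direction, a number no higher from compound 3 to compound 4 (the limit leaves the size open), within the usual scatter. For compound 4 the half-life is estimated at 3 h, with a range from 1.5 h to 6 h.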

Compound 4, half-life: 2.39 h
For compound 4 the middle estimate is 1.3-fold (0.10 log units) above the measured one; low and high end bracket the measured number.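

Compound 4 is the only compound here with a number rather than a limit in this assay, so this position can read below the ceiling that holds the others: the limit of > 3 h in this assay, at which 3 of the 4 values shown sit.
Cyclohexyl in place of cyclopropyl gives an at least 1.2-fold lower number from compound 3 to compound 4 (0.09 log units; that floor lies within the scatter), which is only a floor and does not establish a real loss of half-life.
The value of compound 3, > 3 h, is a limit and not a number.
From the compounds shown here alone, the true size of this step stays open, as does the effect of an amine or a carboxylic acid on this saturated chain carbon.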